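A few compounds are considered here, and "the series" means these few. Any claim that something is new, unique, unknown or untested is made for them only; others in the source may bear on it.

Compound 3 `COc1cc(N(C)C)c(NC(=O)c2ccncn2)cc1Nc1nccc(-c2cn(C)c3ccccc23)n1` gives the lowest number of the three compounds measured in a functional assay on NCI-H1975 cells (Homo sapiens) for antiproliferative activity, read by MTT assay, with a stated time of 72 h (a higher number here means a weaker inhibitor, a lower number a stronger inhibitor), at 1250 nM. Its nearest neighbour is compound 2 `COc1cc(N(C)C)c(NC(=O)c2ccnc(Cl)c2)cc1Nc1nccc(-c2cn(C)c3ccccc23)n1`, which gives 9200 nM in this assay, and the furthest is compound 1 `COc1cc(F)c(NC(=O)c2nccn2C)cc1Nc1nccc(-c2cn(C)c3ccccc23)n1`, which gives 10600 nM. Among the measured compounds shown here, the only single-point step among the measured compounds is a 7.4-fold lower number from compound 2 to compound 3 (0.87 log units; beyond the scatter), a change at the same carbonyl carbon that is altered again here.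

Compound 4 `COc1cc(N(C)C)c(NC(=O)c2nccn2C)cc1Nc1nccc(-c2cn(C)c3ccccc23)n1` differs from compound 3 by 1-methyl-1H-imidazol-2-yl in place of pyrimidin-4-yl on a carbonyl carbon. For the measured compounds named here, no measured step covers this particular exchange, so the step from compound 2 to compound 3 tells only that the group on that carbonyl carbon can move the number well beyond the scatter. Compound 1 carries the same 1-methyl-1H-imidazol-2-yl carbonyl on a different core and gives 10600 nM, a weak number, but its core differs from that of compound 4 in more than this group, so it is an indication rather than a measured step.

On that basis the step of a 3.2-fold higher number from compound 3 to compound 4 (0.51 log units; beyond the scatter) is expected to go towards a higher number, with wide uncertainty. For compound 4 the estimate in this assay is 4000 nM, within a range from 1200 nM to 13000 nM.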

Compound 4, half-maximal inhibitory concentration: 2880 nM
Beside the measured number, compound 4's estimate is 1.4-fold (0.14 log units) above it; the range from low to high includes it.
By their numbers in this assay, from the lowest: compound 3; then compound 4; then compounds 2 and 1 (each within the scatter of the next).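

In this assay, among the compounds shown here, the first measured exchange between these two rings on the carbonyl carbon is a 2.3-fold higher number from compound 3 to compound 4 (0.36 log units; beyond the scatter), so with the same counts of heavy atoms, donors and acceptors, 1-methyl-1H-imidazol-2-yl does not match pyrimidin-4-yl. The same group still compares well with 2-chloropyridin-4-yl, with a 3.2-fold lower number from compound 2 to compound 4 (0.50 log units; beyond the scatter), which shows that the three groups on this carbonyl carbon do not give one common number on the shared core. For the compounds shown here, the first step at a second place, a 3.7-fold lower number from compound 1 to compound 4 (0.57 log units; beyond the scatter), shows that dimethylamino in place of fluoro on an aromatic carbon also moves the number beyond the scatter while the (1-methyl-1H-imidazol-2-yl)carbonyl stays fixed, and nothing available explains any of these steps.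

The compounds shown leave open whether the step from fluoro to dimethylamino would be of similar size with a (pyrimidin-4-yl)carbonyl in place of the (1-methyl-1H-imidazol-2-yl)carbonyl. They also leave open how a non-aromatic group on the carbonyl carbon, such as a piperidine or a short chain ending in an amine, would compare with the aromatic rings seen there so far.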